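From Thiazolyl to Pyridinyl on the Alkyne Arm

The source may report more compounds than this note shows. Statements on the series, on what has been measured and on what is new or still open speak of the compounds shown alone.

Two compounds share one core. Compound 1 `O=C(O)CCc1ccc(C#Cc2cccnc2)cc1` carries a pyridin-3-yl on the triple-bonded carbon, and in an in vitro functional assay on 1321-N1 cells for agonist activity at Free fatty acid receptor 1 (Homo sapiens), read by fluorescence, spectrophotometry and calcium flux (on this read-out lower numbers stand for smaller maximal responses and higher numbers for larger maximal responses), compound 1 gives 96%. Compound 2 `O=C(O)CCc1ccc(C#Cc2cncs2)cc1` carries a 1,3-thiazol-5-yl at that place, and in this assay compound 2 gives 99%. Among the compounds with values here, the single measured step, a number 3 percentage points higher from compound 1 to compound 2 (within the scatter), shows that the two values cannot be told apart, so compound 2 stands level with compound 1 in this assay, both close to the reference response.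

Compound 3 `O=C(O)CCc1ccc(C#Cc2ccccn2)cc1` is the unmeasured member. Relative to compound 2 it changes as follows: pyridin-2-yl in place of 1,3-thiazol-5-yl on a triple-bonded carbon. Within the data shown here, only the step from compound 1 to compound 2 bears on this change, since it too exchanged one heteroaryl for another on the triple-bonded carbon, and that step was within the scatter. On that basis no step beyond the scatter is expected in this assay for compound 3. The expected step for compound 3 is a number 2 percentage points lower from compound 2 to compound 3 (within the scatter). Compound 3 is therefore estimated to give 97% in this assay, with a range from 85% to 106%.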

Compound 3, largest response reached (reported as efficacy), in percent of the reference or control that the assay uses: 98%
Compound 3: middle estimate off by 1 percentage points, on the low side; low and high end bracket the measured number.
By their numbers in this assay, from the lowest: compounds 1, 3 and 2 (each within the scatter of the next).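

In this assay, replacing the 1,3-thiazol-5-yl with pyridin-2-yl on the triple-bonded carbon amounts to a number 1 percentage points lower from compound 2 to compound 3 (within the scatter), although the ring size and the count of hetero atoms both differ between the group that leaves and the group that enters. Exchanging pyridin-3-yl for pyridin-2-yl at the same place amounts to a number 2 percentage points higher from compound 1 to compound 3 (within the scatter), so the two pyridinyl groups cannot be told apart, and all three pairs of heteroaryl groups at this place now lie within the scatter. No evidence is available to explain why the response stays level across these groups.

The compounds shown leave open whether a plain phenyl, a pyridin-4-yl or a pyridinyl ring bearing an amine at this place would also stay level with these three compounds in this assay. Within the data shown here, since no step among them goes beyond the scatter, they also do not show which change at this place, if any, would alter the maximal response.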